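From 1,3-benzothiazol-2-yl to 1H-benzimidazol-2-yl at the assay limit

The source may report more compounds than this note shows. Statements on the series, on what has been measured and on what is new or still open speak of the compounds shown alone.

In an ADME assay on Raji cells (Homo sapiens) for cytotoxicity, with a stated time of 72 h (a lower number here means that less compound is needed, a higher number that more compound is needed for the effect), compound 3 `O=C(Nc1cccc(-c2nc3ccccc3s2)c1)c1cc([N+](=O)[O-])ccc1Cl` gives only a limit, > 27000 nM. Compound 1 `O=C(Nc1cccc(-c2nc3ccccc3s2)c1)c1cc([N+](=O)[O-])c(O)cc1Cl` also gives only a limit, > 25000 nM. Compound 2 `O=C(Nc1ccc(O)c(-c2nc3ccccc3s2)c1)c1cc([N+](=O)[O-])ccc1Cl` likewise gives only a limit, > 25000 nM. Compound 4 `O=C(Nc1cccc(-c2nc3ccccc3[nH]2)c1)c1cc([N+](=O)[O-])ccc1Cl` departs from compound 3 in one place: 1H-benzimidazol-2-yl in place of 1,3-benzothiazol-2-yl on an aromatic carbon. The measured steps that bear on this are a step that the two limits leave unreadable from compound 1 to compound 3 and a step that the two limits leave unreadable from compound 2 to compound 3. Neither has a readable size, and neither alters the 1,3-benzothiazol-2-yl group. Among the measured compounds shown here, with no sized step to draw on, no change beyond the scatter is expected in this assay. The expected step is a number no higher from compound 3 to compound 4 (the limit leaves the size open). Compound 4 is estimated at 27000 nM, with an expected range of 9000 nM to 50000 nM.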

Compound 4, half-maximal effective concentration: 20700 nM
Compound 4: the middle estimate sits 1.3-fold (0.12 log units) above what was measured; the measured number falls inside the stated range.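

In this assay, compound 4 is the only compound shown with a number rather than a limit, and 1H-benzimidazol-2-yl in place of 1,3-benzothiazol-2-yl gives the first readable step: an at least 1.3-fold lower number from compound 3 to compound 4 (0.11 log units; that floor lies within the scatter). The earlier steps shown here, both concerning hydroxy, cannot be read. Compound 3 gives only a limit, and because of this the full size of the step stays open: the limit of > 27000 nM in this assay, at which 1 of the 4 values shown sits.

The compounds shown leave open whether a methyl group on the ring nitrogen of 1H-benzimidazol-2-yl, or an amine in place of the nitro group, would give a step beyond the scatter.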